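The source may hold more compounds than are shown below. What is called first, only, known or untested is meant among the compounds shown, and "the series" means these compounds.

Three compounds share one core and differ only in the group attached to an aromatic carbon. Compound 1 `CCOC(=O)CCCCCOc1cccc(CN(C(=O)c2ccc(-c3cccc(-c4ccccc4)c3)cc2)C(C)C)c1` carries 3-phenylphenyl there, compound 2 `CCOC(=O)CCCCCOc1cccc(CN(C(=O)c2ccc(-c3ccoc3)cc2)C(C)C)c1` carries furan-3-yl, and compound 3 `CCOC(=O)CCCCCOc1cccc(CN(C(=O)c2ccc(-c3ccc4c(c3)OCCO4)cc2)C(C)C)c1` carries 2,3-dihydro-1,4-benzodioxin-6-yl. In an ADME assay on Raji cells (Homo sapiens) for cytotoxicity, read by CellTiter-Glo and resazurin assay, with a stated time of 72 h (on this read-out higher numbers stand for an effect only at larger amounts of compound and lower numbers for an effect already at smaller amounts), compound 1 gives > 26000 nM, which is a limit of the assay rather than a number. In this assay compound 2 gives > 26000 nM, again a limit. Compound 3 gives > 24400 nM, also a limit. Because all three values are limits, the steps a step that the two limits leave unreadable from compound 1 to compound 2, a step that the two limits leave unreadable from compound 1 to compound 3 and a step that the two limits leave unreadable from compound 2 to compound 3 cannot be sized; what is known is the limit of > 26000 nM in this assay, at which 2 of the 3 values shown sit, and (the limit of > 24400 nM in this assay, at which 1 of the 3 values shown sits).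

Compound 4 `CCOC(=O)CCCCCOc1cccc(CN(C(=O)c2ccc(-c3cccc(Cl)c3)cc2)C(C)C)c1` takes the next step from compound 3: 3-chlorophenyl in place of 2,3-dihydro-1,4-benzodioxin-6-yl on an aromatic carbon. Going by the values given here, none of the measured steps is readable, so they give no direction for this change; they show only that every group tried so far at this position left the compound without a measurable effect within the tested range. The expectation is therefore that compound 4 behaves like compound 3 and that a step that the limit leaves unreadable from compound 3 to compound 4 is no step beyond the scatter. Compound 4 is estimated at 30000 nM in this assay, within a range from 15000 nM to 60000 nM, most likely reported again only as a limit.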

Compound 4, half-maximal effective concentration: > 18400 nM
Compound 4: a limit, no number; the forecaster's own chance of this, stated with the estimate: 85%; the middle value lies beyond the limit too.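

No new step can be read: compound 4, like compound 1, compound 2 and compound 3, has only a limit in this assay, not a number. The compounds shown leave open whether any group at this position gives a measurable effect in this assay, and how far these four compounds differ from one another.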